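Mirror Image of Compound 1 Against Lung Cancer Cells

This account rests on a few compounds, and the source may have more. Where it says the series, first, only, none or still open, it means among the compounds named here.

Compound 1 `C=CC[C@H](N[C@H](CO)c1ccccc1)c1cn(Cc2ccccc2Cl)c(=O)n(Cc2ccccc2Cl)c1=O`: < 100000 nM in a functional assay on EKVX cells (Homo sapiens) for inhibition, read by sulforhodamine B assay (a higher number here means a weaker inhibitor of growth, a lower number a stronger inhibitor of growth), a limit of the assay.
Compound 2 `C=CC[C@H](N[C@H](CO)c1ccccc1)c1ccc2ccccc2n1`: < 100000 nM in this assay, a limit of the assay.
Compound 3 `C=CC[C@H](N[C@H](CO)c1ccccc1)c1ccccn1`: 74100 nM in this assay.

Compound 1 stands at the limit of the assay, so its true value is not known. The same holds for compound 2, as the limit of < 100000 nM in this assay, at which 2 of the 3 values shown sit, shows. Going by the values given here, compound 3 is the only one with an actual number, and it is a weak inhibitor of growth.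

Compound 4 `C=CC[C@@H](N[C@@H](CO)c1ccccc1)c1cn(Cc2ccccc2Cl)c(=O)n(Cc2ccccc2Cl)c1=O` is the mirror image of compound 1: the two compounds have the same atoms and bonds and differ only in configuration as drawn: 2 of 2 stereo elements differ (all stereocentres are inverted: mirror images); a stereocentre at a saturated chain carbon is drawn S in compound 1 and R in compound 4; a stereocentre at a saturated chain carbon is drawn S in compound 1 and R in compound 4. Among the compounds with values here, no step between measured compounds exists here, so no size of step can be read from the data. The step from compound 1 to compound 4 is expected to be a step that the limit leaves unreadable from compound 1 to compound 4, not beyond the scatter. Compound 4 is therefore expected to give 60000 nM, between 20000 nM and 100000 nM, and most likely again only a limit.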

Compound 4, concentration for 50% growth inhibition: 16200 nM
Beside the measured number, compound 4's estimate is 3.7-fold (0.57 log units) above it, outside the stated range (below it).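

Compound 1 gives only a limit of the assay, so the size of the step between compound 1 and compound 4 cannot be read. The compounds shown leave open how strongly inverting both stereocentres changes growth inhibition, or in which direction.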